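From sulfanyl to sulfonyl on a shared core

The source may hold more compounds than are shown below. What is called first, only, known or untested is meant among the compounds shown, and "the series" means these compounds.

Compound 1 `Cc1ccc(S/C(=C/c2c[nH]c3ccc(Cl)cc23)C(=O)c2ccc(Br)cc2)cc1` gives 1000 nM
Compound 2 `Cc1ccc(S/C(=C/c2c[nH]c3ccc(Cl)cc23)C(=O)c2ccc(Cl)cc2)cc1` gives 1000 nM

In a functional assay on DU-145 cells (Homo sapiens) for inhibition, read by trypan blue exclusion, with a stated time of 96 h (a lower number here means a stronger inhibitor of growth, a higher number a weaker inhibitor of growth), compound 1 stands level with compound 2 at the digits shown, and no other compound has been measured. Compound 3 `Cc1ccc(S(=O)(=O)/C(=C/c2c[nH]c3ccc(Cl)cc23)C(=O)c2ccc(Br)cc2)cc1` keeps the core of compound 1 but carries (4-methylphenyl)sulfonyl in place of (4-methylphenyl)sulfanyl on a double-bonded chain carbon bound to a carbonyl carbon and a double-bonded chain carbon and still awaits measurement. Going by the values given here, the only measured step of no change at the digits printed from compound 1 to compound 2 (within the scatter) puts chloro in place of bromo on an aromatic carbon and leaves the sulfur group untouched. It therefore gives no direct guide to this change, and no direction can be drawn from it. The expected result in this assay is no change at the digits printed from compound 1 to compound 3 (within the scatter) and this means no step beyond the scatter is forecast. The estimated value for compound 3 is 1000 nM within an expected range of 200 nM to 5000 nM as a deliberately wide guess.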

Compound 3, concentration for 50% growth inhibition: 10000 nM
Compound 3: the middle estimate sits 10-fold (1.00 log units) below what was measured, outside the stated range (above it).
By their numbers in this assay, from the lowest: compounds 1 and 2 (each within the scatter of the next); then compound 3.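

In this assay the change of sulfur group gives a 10-fold higher number from compound 1 to compound 3 (1.00 log units; beyond the scatter) and so a weaker inhibitor of growth, while the earlier pair, which swapped only bromo for chloro on an aromatic carbon, left this group untouched. This shows that the double-bonded chain carbon bound to a carbonyl carbon and a double-bonded chain carbon is a place where the shared core responds to a change, and that here (4-methylphenyl)sulfanyl goes with the stronger result of the two. Nothing measured here explains the loss of growth inhibition.

As far as these compounds go, it remains open whether the same swap would act alike on the chloro compound 2. From the compounds shown here alone, it is also open where a sulfinyl group, or a plain ether oxygen in place of the sulfur, would fall relative to compound 1 and compound 3.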